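Sulfanyl for benzylamino on the shared core

The source may report more compounds than this note shows. Statements on the series, on what has been measured and on what is new or still open speak of the compounds shown alone.

The series is followed in a functional assay on EL4 cells (Mus musculus) for inhibition, tested at 100 uM; a higher number here means more inhibition at the concentration tested (going by the name of the read-out), a lower number less inhibition. Going by the values given here, compound 1 `OC[C@H]1O[C@@H](n2cnc3c(NCc4ccccc4)nccc32)C[C@@H]1O` carries a benzylamino group on its core, and in this assay compound 1 gives 8%, the only value in the set that is a plain number. Compound 2 `Clc1[nH]ccc2ncnc1-2` is a smaller fragment of the same core; in this assay compound 2 gives < 5%, which is a limit of the assay and not a number, so that compound 2 stands at the limit of < 5% in this assay, at which 1 of the 2 values shown sits. Among the compounds with values here, no step between two measured compounds can be drawn, since no pair differs in a single place.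

Compound 3 `OC[C@H]1O[C@@H](n2cnc3c(S)nccc32)C[C@@H]1O` is the not yet measured member. Compared with compound 1 the change is sulfanyl in place of benzylamino on an aromatic carbon. With compound 1 already near the foot of the scale and compound 2 at the limit, no step beyond the usual scatter is expected in either direction from compound 1 to compound 3: a number 2 percentage points lower from compound 1 to compound 3 (within the scatter). For compound 3 the expected value is 6%, with a range from 0% to 18%, and a fair chance that only the limit is reported.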

Compound 3, a percentage reported as inhibition, at one concentration (the size of the read-out at that concentration, not a potency): < 5%
Compound 3: only a limit was reported; the forecaster's own chance of this, stated with the estimate: 40%; middle value at least 1 percentage points away from the limit.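

Going by these compounds alone, this is the first comparison in the set between two compounds that differ in one place. In this assay compound 3 gives < 5%, a limit of the assay and not a number. Sulfanyl in place of benzylamino on an aromatic carbon, next to the ring nitrogen, removes the benzylamino group and its six-membered aromatic ring of carbon only, and the change reads as a number at least 3 percentage points lower from compound 1 to compound 3 (that floor lies within the scatter), so this large swap in group size at this position brings no step printed as beyond the scatter, and the series stays gathered at the foot of this assay: the limit of < 5% in this assay, at which 2 of the 3 values shown sit.

Open, going by these compounds, is whether any group on this aromatic carbon lifts inhibition clear of the limit, and a plain amine, a methoxy group or a longer alkylamino chain in the same place would bear on that. With the one plain number this close to the limit, the compounds shown cannot tell whether benzylamino contributes anything at all to the small inhibition seen with compound 1, nor how far sulfanyl truly lies from it.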